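Compound 1 and an added isopropoxy group

This account rests on a few compounds, and the source may have more. Where it says the series, first, only, none or still open, it means among the compounds named here.

Compound 1 `COc1ccc(C2=C(c3cc(OC)c(OC)c(OC)c3)C(=O)C(O)C2)cc1`: < 1 ug/mL in an ADME assay on KB cells (Homo sapiens) for cytotoxicity, read by MTT assay, with a stated time of 72 h; on this read-out higher numbers stand for weaker inhibition and lower numbers for stronger inhibition (a limit)
Compound 2 `COc1ccc(C2=C(c3cc(OC)c(OC)c(OC)c3)C(=O)C(O[SiH2]C(C)(C)C)C2)cc1`: 7 ug/mL in this assay

Compound 1 stands at the limit of < 1 ug/mL in this assay, at which 1 of the 2 values shown sits, and is therefore known by a limit and not by a number. Compound 3 `COc1ccc(C2=C(c3cc(OC)c(OC)c(OC)c3)C(=O)C(O)C2)cc1OC(C)C` keeps the core of compound 1 and differs in one place (isopropoxy in place of hydrogen on an aromatic carbon) on an aromatic carbon, ortho to a methoxy group. Among the compounds with values here, only one measured step bears on this, and loosely: an at least 7.0-fold higher number from compound 1 to compound 2 (0.84 log units; beyond the scatter) comes from a group added on an oxygen on a saturated carbon, not on the aromatic ring. Going by that step, a rise of similar or smaller size is expected in this assay and would mean weaker inhibition, although a change within the scatter remains possible. The expected change is an at least 1.5-fold higher number from compound 1 to compound 3 (0.17 log units; that floor lies within the scatter) as an estimate resting on a limit. For compound 3 the estimated value is 1.5 ug/mL within an expected range of 0.3 ug/mL to 8 ug/mL in this assay.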

Compound 3, half-maximal inhibitory concentration: > 100 ug/mL
Compound 3: only a limit was reported; the forecaster's own chance of this, stated with the estimate: 40%; middle value at least 66-fold (1.82 log units) from the limit.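

In this assay, isopropoxy in place of hydrogen on an aromatic carbon, ortho to a methoxy group, gives an at least 100-fold higher number from compound 1 to compound 3 (2.00 log units; beyond the scatter), which stands for much weaker inhibition. Until now only a group on an oxygen on a saturated carbon had been seen to raise the number, so this step shows that a change on the aromatic ring can do so as well, and by a large margin. Compound 3 is known only by a limit, so the step gives a floor and not a full size: the limit of > 100 ug/mL in this assay, at which 1 of the 3 values shown sits.

On these data alone, whether a hydroxyl group, a fluorine atom or an amine on this same aromatic carbon would keep the inhibition of compound 1 remains open. Also open, as far as these compounds go, is whether the loss comes with any group at this place or only with isopropoxy.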